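Trading a Methyl for Hydrogen on Compound 3

The source may hold more compounds than are shown below. What is called first, only, known or untested is meant among the compounds shown, and "the series" means these compounds.

Three related compounds have been tested in a functional assay on Ehrlich cells (Mus musculus) for cytotoxicity; a lower number here means a stronger inhibitor, a higher number a weaker inhibitor. Compound 1 `COc1cc(N2C(N)=C(C#N)C(c3cccc([N+](=O)[O-])c3)C3=C2CC(C)(C)CC3=O)cc(OC)c1OC` was "not active" (no number reported), so no number is available for it. Compound 2 `COc1cc(N2C(N)=C(C#N)C(c3ccc([N+](=O)[O-])cc3)C3=C2CC(C)(C)CC3=O)cc(OC)c1OC` gives 25000 nM in this assay. Compound 3 `COc1cc(N2C(N)=C(C#N)C(c3ccc(C)cc3)C3=C2CC(C)(C)CC3=O)cc(OC)c1OC` gives 52900 nM, the highest of the two reported numbers; its nearest neighbour is compound 2, and the gap between them is a 2.1-fold higher number from compound 2 to compound 3 (0.33 log units; beyond the scatter).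

Compound 4 `COc1cc(N2C(N)=C(C#N)C(c3ccccc3)C3=C2CC(C)(C)CC3=O)cc(OC)c1OC` differs from compound 3 in one place: hydrogen in place of methyl on an aromatic carbon. Among the measured compounds shown here, no measured pair shows exactly this change. For the measured compounds named here, the only step that bears on it is a 2.1-fold higher number from compound 2 to compound 3 (0.33 log units; beyond the scatter), which also exchanged the group on that same aromatic carbon and moved the number only modestly. A change of the same kind at the same place is therefore expected to give a small step, a 1.1-fold higher number from compound 3 to compound 4 (0.05 log units; within the scatter), with no clear direction beyond the scatter. Compound 4 is expected to give about 60000 nM in this assay, within a range from 25000 nM to 150000 nM. Since compound 1 was "not active" (no number reported), an inactive result for compound 4 cannot be ruled out either.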

Compound 4, half-maximal inhibitory concentration: "not active" (no number reported)
For compound 4 the study gives words and no number; the estimate stays without a comparison.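

Among the compounds shown here, compound 4 came back as "not active" (no number reported), so no step from compound 3 to compound 4 can be read. The compounds shown leave open how large the effect of trading the methyl for hydrogen really is. Nothing shown accounts for this result.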